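The source may report more compounds than this note shows. Statements on the series, on what has been measured and on what is new or still open speak of the compounds shown alone.

Working notes on the series. In an ADME assay on HEp-2 cells (Homo sapiens) for cytotoxicity, read by CCK-8 assay, with a stated time of 5 days (on this read-out lower numbers stand for higher toxicity in this test and higher numbers for lower toxicity in this test), compound 1 `COc1ccc2nc(N3CCCc4ccccc4C3)cc(NCCN)c2c1` gives 4800 nM. In this assay compound 2 `NCCNc1cc(N2CCCc3ccccc3C2)nc2ccc(F)cc12` gives 8000 nM, and compound 3 `CNCCNc1cc(N2CCCc3ccc(F)cc3C2)nc2ccc(C)cc12` gives 29000 nM. On these three numbers compound 3 stands highest; its gap to compound 2 is the smaller of its two gaps and its gap to compound 1 the larger, and both gaps lie beyond the scatter. Within the data shown here, the one measured step, a 1.7-fold higher number from compound 1 to compound 2 (0.22 log units; within the scatter), concerns a substituent on an aromatic carbon and lies within the scatter.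

Compound 4 `Cc1ccc2nc(N3CCCc4ccc(F)cc4C3)cc(NCCO)c2c1` differs from compound 3 by hydroxy in place of methylamino on a saturated chain carbon, two bonds along the chain from a nitrogen on an aromatic ring. Among the measured compounds shown here, no measured step touches the terminus of this chain, so nothing in this assay speaks directly to the change; the only step that exists is small and elsewhere in the molecule. The expectation is therefore a number close to that of compound 3, with no step beyond the scatter, and the range is kept wide for lack of a bearing step. Compound 4 is estimated at 22000 nM, between 8000 nM and 60000 nM, which means an expected 1.3-fold lower number from compound 3 to compound 4 (0.12 log units; within the scatter).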

Compound 4, half-maximal cytotoxic concentration: > 100000 nM
Compound 4 was reported as a limit; the forecaster's own chance of this, stated with the estimate: 10%; middle value at least 4.5-fold (0.65 log units) from the limit.
By their numbers in this assay, from the lowest: compounds 1 and 2 (each within the scatter of the next); then compound 3. At a limit, above all of these: compound 4.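

In this assay compound 4 gives > 100000 nM, which is a limit of the assay and not a number. Hydroxy in place of methylamino on a saturated chain carbon, two bonds along the chain from a nitrogen on an aromatic ring, gives an at least 3.4-fold higher number from compound 3 to compound 4 (0.53 log units; beyond the scatter), the first measured step at this place and the first step in the series beyond the scatter. The number in this test therefore responds to this exchange, towards lower toxicity, whereas the earlier change on an aromatic carbon, a 1.7-fold higher number from compound 1 to compound 2 (0.22 log units; within the scatter), did not leave the scatter.

As far as these compounds go, whether dimethylamino, methoxy or a longer chain at this place would stay near compound 3 or reach the limit of compound 4 remains open. Also open, from the compounds shown here alone, are the true size of this step and whether the same exchange gives a comparable step in the setting of compound 1 or compound 2.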